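Swapping chloro for methylamino on a diphenylacetylene scaffold

A few compounds are considered here, and "the series" means these few. Any claim that something is new, unique, unknown or untested is made for them only; others in the source may bear on it.

Three compounds that share a two-ring aromatic unit joined through a triple bond to a difluorinated phenyl ring have been measured in a functional assay on LS174T cells (Homo sapiens) for inhibition, with a stated time of 4 days, tested at 10 uM; a higher number here means a stronger effect of the compound at the concentration tested, a lower number a weaker effect. Compound 1 `CN1CCN(c2ccc(C#Cc3c(F)cccc3F)cc2)CC1` gives 99.6%. Compound 2 `Fc1cccc(F)c1C#Cc1cnc(Cl)c2ccccc12` gives 94% in this assay, and compound 3 `Fc1cccc(F)c1C#Cc1ccc2ccccc2n1` gives 93.8%. All three numbers sit close together: the difference between compound 2 and compound 3 is tiny, and the difference between compound 2 and compound 1 also stays within the usual scatter of this kind of measurement, so none of the three can be set apart from the others.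

Compound 4 `CNc1ncc(C#Cc2c(F)cccc2F)c2ccccc12` has not yet been measured. It follows from compound 2 by the change (methylamino in place of chloro on an aromatic carbon). Among the compounds with values here, no measured pair in this set shows what such a change does, so the expectation rests only on the fact that every compound measured so far reaches nearly complete inhibition. For compound 4 the value in this assay is expected to be 90%, within a range from 72% to 100%. The expected step of a number 4 percentage points lower from compound 2 to compound 4 (within the scatter) is therefore small, most likely within the scatter, with a slight lean toward a weaker effect to allow for the untested group.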

Compound 4, a percentage reported as inhibition, at one concentration (the size of the read-out at that concentration, not a potency): 98.9%
Beside the measured number, compound 4's estimate is 8.9 percentage points below it, and the stated range covers the measured number.
By their numbers in this assay, from the lowest: compounds 3, 2, 4 and 1 (each within the scatter of the next).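

In this assay, placing methylamino instead of chloro on the aromatic carbon next to the ring nitrogen gives a number 4.9 percentage points higher from compound 2 to compound 4 (within the scatter), so this position accepts a group carrying a hydrogen-bond donor with no change that stands out from the scatter. Within the data shown here, this is the first pair in the set that differs in only one place, and so the first direct reading of a single change on this core. Nothing available gives a measured reason for this outcome.

The read-out comes from one concentration and sits near complete inhibition, so any difference in potency between compound 2 and compound 4 could remain hidden. From the compounds shown here alone, it also remains open whether a bulkier amine such as morpholine, or a carboxylic acid, would be accepted at this position as well.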